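The source may report more compounds than this note shows. Statements on the series, on what has been measured and on what is new or still open speak of the compounds shown alone.

Measured so far:
compound 1 `CCCOC(=O)C1=C(C)N(C)C(=O)NC1c1ccco1` 23%
compound 2 `CC1=C(C(=O)OCc2ccccc2)C(c2ccco2)NC(=O)N1C` 41%

In an assay on membranes from HEK293 cells for displacement of a labelled ligand from adenosine receptor A2b (Homo sapiens), read by scintillation counting, with a stated time of 30 min, tested at 1 uM (a lower number here means less inhibition, a higher number more inhibition at the concentration tested (going by the name of the read-out)), compound 1 gives 23%, the lower of the two numbers shown. Within the data shown here, the only measured step, a number 18 percentage points higher from compound 1 to compound 2 (beyond the scatter), comes from phenyl in place of ethyl on a saturated chain carbon bound to an oxygen next to a carbonyl group; the ring on the saturated ring carbon is untouched by it.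

Compound 3 `CCCOC(=O)C1=C(C)N(C)C(=O)NC1c1cccs1` is the next compound to be measured in this assay. It differs from compound 1 by thiophen-2-yl in place of furan-2-yl on a saturated ring carbon. Among the measured compounds shown here, no measured step bears on this change: neither compound 1 nor compound 2 varies the ring at that place, so the one step measured gives no guide here. The expectation is therefore no step beyond the scatter in this assay from compound 1 to compound 3, the number staying near that of compound 1.

For compound 3 the estimated value in this assay is 26%, with a range of 10% to 45%, which means an expected step of a number 3 percentage points higher from compound 1 to compound 3 (within the scatter).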

Compound 3, a percentage reported as inhibition, at one concentration (the size of the read-out at that concentration, not a potency): 1%
For compound 3 the middle estimate is 25 percentage points above the measured one; the whole stated range lies above it.
By their numbers in this assay, from the lowest: compound 3; then compound 1; then compound 2.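

In this assay, the ring on the saturated ring carbon proves to matter: thiophen-2-yl in place of furan-2-yl gives a number 22 percentage points lower from compound 1 to compound 3 (beyond the scatter) even though the two groups match in heavy-atom count, ring size and hydrogen-bond donors and acceptors. They differ in the ring hetero atom, sulfur for oxygen, so exchanging that single atom at this position is enough to move the number beyond the scatter, which compound 1 and compound 2 could not show as both carry furan-2-yl there. Nothing at hand explains why this exchange lowers the number.

Going by these compounds, whether thiophen-2-yl has a similar effect alongside the ester of compound 2, which carries phenyl in place of ethyl, remains open. On these data alone, how a plain phenyl ring or a pyridine ring would read on the same saturated ring carbon also remains open.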